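Swapping Halogens on the Aryl Arm of Compound 2

This account rests on a few compounds, and the source may have more. Where it says the series, first, only, none or still open, it means among the compounds named here.

Of the compounds shown here, two of a shared core have been measured so far. Compound 1 `COc1ccc(-c2nc3ccccc3n2CCCN2CCC(c3cccc(NC(C)=O)c3)CC2)cc1` gives 9 nM in an assay for displacement of a labelled ligand from melanin-concentrating hormone receptor 1 (Homo sapiens), read by fluorescence; on this read-out higher numbers stand for weaker inhibition and lower numbers for stronger inhibition. Among the measured compounds shown here, compound 2 `CC(=O)Nc1cccc(C2CCN(CCCn3c(-c4ccc(Cl)cc4Cl)nc4ccccc43)CC2)c1` gives 3 nM in this assay, the lowest of the two numbers; the only measured step, a 3.0-fold lower number from compound 1 to compound 2 (0.48 log units; beyond the scatter), separates them. The next compound, compound 3 `CC(=O)Nc1cccc(C2CCN(CCCn3c(-c4ccc(F)c(F)c4)nc4ccccc43)CC2)c1`, differs from compound 2 in one place: 3,4-difluorophenyl in place of 2,4-dichlorophenyl on an aromatic carbon. For the measured compounds named here, no measured step exchanges one halogenated ring for another, so the single step from compound 1 to compound 2 bears only loosely on this change, showing that the group at this position can shift the number modestly. Compound 3 is expected to sit near compound 2, most likely a little higher, with the step of a 1.7-fold higher number from compound 2 to compound 3 (0.22 log units; within the scatter) estimated within the scatter. The estimate for compound 3 is 5 nM, with a range from 1.5 nM to 18 nM.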

Compound 3, half-maximal inhibitory concentration: 4 nM
Compound 3: middle estimate off by 1.3-fold (0.10 log units), on the high side; measured number inside the range.
By their numbers in this assay, from the lowest: compounds 2 and 3 (each within the scatter of the next); then compound 1.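

The exchange of the halogenated ring gives a 1.3-fold higher number from compound 2 to compound 3 (0.12 log units; within the scatter) in this assay so this position, between two ring nitrogen atoms, accepts either 2,4-dichlorophenyl or 3,4-difluorophenyl with no difference that can be told from the scatter. Set against the ring of compound 1, 3,4-difluorophenyl gives a 2.3-fold lower number from compound 1 to compound 3 (0.35 log units; beyond the scatter) and so, among these three compounds, both halogenated rings sit at lower numbers than 4-methoxyphenyl, with no compound here going against that. Nothing available here offers an explanation for these results.

From the compounds shown here alone, it remains open whether halogens matter at all at this position, a question that a plain phenyl ring or a phenyl ring bearing a single fluorine would address. A pyridine ring or a phenyl ring carrying an amine also remains an open case.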